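The compounds below may be only part of what the source reports. "The series", "measured", "known", "first", "only" and "open" are said of these compounds alone.

Compound 1 `N[C@@H](COP(=O)(O)OCCCOC(=O)CCc1ccccc1OCc1cccc(Oc2ccccc2)c1)C(=O)O`: 19.4%
Compound 2 `Cc1cccc(Oc2cccc(COc3ccccc3CCC(=O)OCCCOP(=O)(O)OC[C@H](N)C(=O)O)c2)c1`: 21.3%
Compound 3 `N[C@@H](COP(=O)(O)OCCCOC(=O)CCc1ccccc1OCc1cccc(Oc2ccccc2Cl)c1)C(=O)O`: 19.8%

In an assay on cells for agonist activity at probable G-protein coupled receptor 34 (Mus musculus), with a stated time of 1 h (on this read-out higher numbers stand for larger maximal responses and lower numbers for smaller maximal responses), compound 2 sits within the scatter of both companions: a number 1.9 percentage points higher from compound 1 to compound 2 (within the scatter) and a number 1.5 percentage points lower from compound 2 to compound 3 (within the scatter), so the three numbers cannot be told apart. Compound 4 `CCc1ccc(Oc2cccc(COc3ccccc3CCC(=O)OCCCOP(=O)(O)OC[C@H](N)C(=O)O)c2)cc1` is the next step from compound 2, with the change (4-ethylphenyl in place of 3-methylphenyl on an oxygen on an aromatic ring). The step that bears most directly on it is the earlier aryl exchange at the same oxygen, a number 1.5 percentage points lower from compound 2 to compound 3 (within the scatter), and the two ring substitutions a number 1.9 percentage points higher from compound 1 to compound 2 (within the scatter) and a number 0.4 percentage points higher from compound 1 to compound 3 (within the scatter) point the same way: every change so far has left the response where it was. No step beyond the scatter is therefore expected in this assay for compound 4, which is estimated at 20.5% (13% to 28%). The expected change is a number 0.8 percentage points lower from compound 2 to compound 4 (within the scatter).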

Compound 4, largest response reached (Emax), in percent of the reference or control that the assay uses: 19.3%
Beside the measured number, compound 4's estimate is 1.2 percentage points above it; low and high end bracket the measured number.
By their numbers in this assay, from the lowest: compounds 4, 1, 3 and 2 (each within the scatter of the next).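

In this assay the 4-ethylphenyl group on this oxygen cannot be told apart from 3-methylphenyl (a number 2 percentage points lower from compound 2 to compound 4 (within the scatter)), from 2-chlorophenyl (a number 0.5 percentage points lower from compound 3 to compound 4 (within the scatter)) or from plain phenyl (a number 0.1 percentage points lower from compound 1 to compound 4 (within the scatter)). Compound 4 thus extends the flat picture from a methyl and a chloro substituent to an ethyl group, with one more carbon in the entering group than in the one it replaces. No measurement at hand bears on why these numbers coincide. The compounds shown leave open whether a nitrile or an amine on this ring, or a longer chain in place of the ethyl, would give a step beyond the scatter.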